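Tertiary Alcohol Series: Allyl Replacing the Ester Side Chain

The source may hold more compounds than are shown below. What is called first, only, known or untested is meant among the compounds shown, and "the series" means these compounds.

Compound 1 `CCOC(=O)CCO/N=C(/c1ccc(OC)c(OC)c1OC)c1cccc2ccccc12` — 10000 nM
Compound 2 `CCOC(=O)C(C)C(O)(c1ccc(OC)c(OC)c1OC)c1cccc2ccccc12` — > 20000 nM
Compound 3 `COc1ccc(/C(=N/O)c2cccc3ccccc23)c(OC)c1OC` — 5880 nM

In a functional assay on HCT-116 cells (Homo sapiens) for inhibition, read by sulforhodamine B assay, with a stated time of 48 h (a lower number here means a stronger inhibitor, a higher number a weaker inhibitor), compound 1 gives 10000 nM and compound 3 gives 5880 nM. For the measured compounds named here, the one measured step, a 1.7-fold lower number from compound 1 to compound 3 (0.23 log units; within the scatter), concerns the oxime oxygen and is within the scatter. For compound 2 this assay reports only a limit of the assay, > 20000 nM. That limit is the one noted as the limit of > 20000 nM in this assay, at which 1 of the 3 values shown sits. Compound 2 therefore stands at the weak end of the numbers shown, without a number of its own.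

Compound 4 `C=CCC(O)(c1ccc(OC)c(OC)c1OC)c1cccc2ccccc12` differs from compound 2 by allyl in place of 1-(ethoxycarbonyl)ethyl on a saturated chain carbon bound to two aromatic carbons and an oxygen on a saturated carbon. Going by the values given here, no measured step bears on this change: the step from compound 1 to compound 3 alters a different part of the shared core, and both compounds carrying the tertiary alcohol carbon are otherwise unmeasured. With compound 2 itself at a limit, no size can be assigned to the change, and no direction beyond the scatter is expected. Compound 4 is expected near 15000 nM, in a range from 4000 nM to 40000 nM. The step of an at least 1.3-fold lower number from compound 2 to compound 4 (0.12 log units; that floor lies within the scatter) is thus expected to be small, and a further limit is quite possible.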

Compound 4, half-maximal inhibitory concentration: > 20000 nM
Compound 4: no number, only a limit; the forecaster's own chance of this, stated with the estimate: 45%; at least 1.3-fold (0.12 log units) between middle value and limit.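

Compound 2 and compound 4 both stand only at a limit in this assay and the change of 1-(ethoxycarbonyl)ethyl to allyl therefore cannot be read as a step: the limit of > 20000 nM in this assay, at which 2 of the 4 values shown sit.

The compounds shown leave open whether any tertiary alcohol in the series gives a measurable number in this assay and how that series compares with compound 1 and compound 3.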